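This account rests on a few compounds, and the source may have more. Where it says the series, first, only, none or still open, it means among the compounds named here.

Measured so far in an ADME assay on microsomes from liver (Rattus norvegicus) for pharmacokinetics, using NADPH, with a stated time of 30 min, tested at 1 uM; a higher number here means faster removal of the compound, a lower number slower removal:
- compound 1 `CNC(=O)c1c(-c2ccccc2)c([C@H](C)Nc2ncnc(N)c2C#N)nc2ccc(F)cc12`: 15 mL.min-1.g-1
- compound 2 `C[C@H](Nc1ncnc(N)c1C#N)c1nc2ccc(F)cc2c(C(=O)N(C)C)c1-c1ccccc1`: 426 mL.min-1.g-1
- compound 3 `CC(C)NC(=O)c1c(-c2ccccc2)c([C@H](C)Nc2ncnc(N)c2C#N)nc2ccc(F)cc12`: < 14 mL.min-1.g-1 (a limit, not a number)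

Compound 3 stands at the limit of < 14 mL.min-1.g-1 in this assay, at which 1 of the 3 values shown sits.

Compound 4 `C[C@H](Nc1ncnc(N)c1C#N)c1nc2ccc(F)cc2c(C(=O)N2CC(O)C2)c1-c1ccccc1` is not yet measured. Its difference from compound 3 is 3-hydroxyazetidin-1-yl in place of isopropylamino on a carbonyl carbon.

The closest measured change at this place is an at least 30-fold lower number from compound 2 to compound 3 (1.48 log units; beyond the scatter). Adding methyl on the amide-type nitrogen gave a 28-fold higher number from compound 1 to compound 2 (1.45 log units; beyond the scatter), which removes the amide hydrogen. Keeping that hydrogen gave an at least 1.0-fold lower number from compound 1 to compound 3 (0.02 log units; that floor lies within the scatter), with the floor within the scatter.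

Compound 4 also lacks the amide hydrogen, like compound 2 at 426 mL.min-1.g-1. Within the data shown here, a rise in this assay is therefore expected, though smaller than the rise seen for compound 2, since the 3-hydroxyazetidin-1-yl group has no measured precedent in this set.

The expected change is an at least 3.2-fold higher number from compound 3 to compound 4 (0.50 log units; beyond the scatter).

For compound 4 the estimated value is 45 mL.min-1.g-1, with an expected range of 14 mL.min-1.g-1 to 200 mL.min-1.g-1.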

Compound 4, intrinsic clearance in microsomes: 49 mL.min-1.g-1
Compound 4: middle estimate off by 1.1-fold (0.04 log units), on the low side; low and high end bracket the measured number.
By their numbers in this assay, from the lowest: compound 1; then compound 4; then compound 2. At a limit, below all of these: compound 3.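

In this assay, removing the amide hydrogen does not by itself give a number as high as that of compound 2: with 3-hydroxyazetidin-1-yl on the carbonyl carbon, the result is an 8.7-fold lower number from compound 2 to compound 4 (0.94 log units; beyond the scatter). The same group still does not return to the level of the methylamino amide, giving a 3.3-fold higher number from compound 1 to compound 4 (0.51 log units; beyond the scatter), so the carbonyl substituent sets the number over a wider range than the presence or absence of that hydrogen alone would indicate. The third step, an at least 3.5-fold higher number from compound 3 to compound 4 (0.54 log units; beyond the scatter), is only a floor, set by a limit and not by a number: the limit of < 14 mL.min-1.g-1 in this assay, at which 1 of the 4 values shown sits.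

The compounds shown do not separate the contribution of the hydroxyl from that of the four-membered ring. Plain azetidin-1-yl on the same carbonyl carbon would address that, while pyrrolidin-1-yl or morpholin-4-yl would extend the comparison to larger rings.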